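Swapping Bromo for Methyl on the Sulfonyl Aryl Ring

The source may hold more compounds than are shown below. What is called first, only, known or untested is meant among the compounds shown, and "the series" means these compounds.

Of the compounds shown here, two have been measured in a functional assay on A549 cells (Homo sapiens) for antiproliferative activity, read by MTT assay, with a stated time of 48 h; on this read-out lower numbers stand for stronger inhibition and higher numbers for weaker inhibition. Compound 1 `Cc1ncc([N+](=O)[O-])n1CC(=O)NS(=O)(=O)c1ccc(Cl)cc1` gives 2.47 ug/mL in this assay. Compound 2 `Cc1ncc([N+](=O)[O-])n1CC(=O)NS(=O)(=O)c1ccc(Br)cc1` gives 3.03 ug/mL. The two differ in a single halogen on an aromatic carbon: a 1.2-fold higher number from compound 1 to compound 2 (0.09 log units; within the scatter). Within the data shown here, compound 2 thus holds the highest of the two numbers so far, but its only neighbour, compound 1, lies within the scatter of it, so the two cannot be told apart.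

Compound 3 `Cc1ccc(S(=O)(=O)NC(=O)Cn2c([N+](=O)[O-])cnc2C)cc1` has not yet been measured. It differs from compound 2 in one place: methyl in place of bromo on an aromatic carbon. Among the measured compounds shown here, the only measured step, chloro to bromo, bears on this only loosely, since it exchanged one halogen for another and stayed within the scatter. Bromo to methyl is a different kind of exchange, and no measured pair shows it. With nothing in hand pointing either way, the expected step of a 1.0-fold lower number from compound 2 to compound 3 (0.00 log units; within the scatter) is none beyond the scatter. Compound 3 is therefore estimated at 3 ug/mL in this assay, with an expected range from 1.5 ug/mL to 6 ug/mL.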

Compound 3, half-maximal inhibitory concentration: 4.38 ug/mL
For compound 3 the middle estimate is 1.5-fold (0.16 log units) below the measured one; low and high end bracket the measured number.
By their numbers in this assay, from the lowest: compounds 1, 2 and 3 (each within the scatter of the next).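

In this assay, the place on the aromatic ring para to a large group now has a carbon group as well as halogens, and methyl stays close to both: compare methyl for bromo (a 1.4-fold higher number from compound 2 to compound 3 (0.16 log units; within the scatter)) and methyl for chloro (a 1.8-fold higher number from compound 1 to compound 3 (0.25 log units; within the scatter)). The earlier pair exchanged only one halogen for another, so it could not show that a halogen at this place can give way to methyl with all the differences staying inside the usual scatter, which means that compound 1, compound 2 and compound 3 cannot be told apart here. Nothing in hand speaks to what lies behind these numbers.

Bromo and methyl each count as a single heavy atom, so the compounds shown say nothing about whether an amine, a carboxylic acid or a longer chain such as butyl at this same place would stay inside the scatter or leave it. They also leave open whether any group here can move the number clearly in either direction, since every step seen so far at this position lies within the scatter.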